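The source may report more compounds than this note shows. Statements on the series, on what has been measured and on what is new or still open speak of the compounds shown alone.

Measured so far in a physicochemical assay for lipophilicity, in phosphate buffer, at pH 7; on this read-out higher numbers stand for higher lipophilicity and lower numbers for lower lipophilicity:
compound 1 `CCc1cc(-c2noc(-c3cc(C)cc(CN(C)C)c3)n2)cc(C)c1OC[C@@H](O)CNC(=O)CO` — 2.8
compound 2 `CCCCN(C)Cc1cc(C)cc(-c2nc(-c3cc(C)c(OC[C@@H](O)CNC(=O)CO)c(CC)c3)no2)c1` — a limit, > 4.1

Among the measured compounds shown here, compound 1 is the only compound of the pair with an actual number in this assay; compound 2 reaches only a limit (the limit of > 4.1 in this assay, at which 1 of the 2 values shown sits). For the measured compounds named here, the one measured step, a number at least 1.30 log units higher from compound 1 to compound 2 (beyond the scatter), is a different change from the one to compound 3 `CCc1cc(-c2nc(-c3cc(C)c(OC[C@@H](O)CNC(=O)CO)c(CC)c3)no2)ccc1CN(C)C`, which differs from compound 1 by 4-((dimethylamino)methyl)-3-ethylphenyl in place of 3-((dimethylamino)methyl)-5-methylphenyl on an aromatic carbon. That step adds little carbon and keeps the same amine, so in this assay only a small rise is expected, a number 0.30 log units higher from compound 1 to compound 3 (within the scatter). Compound 3 is estimated at 3.1, between 2.6 and 3.6.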

Compound 3, distribution coefficient: 3.8
Compound 3: the middle estimate sits 0.70 log units below what was measured; the measured number lies above the stated range.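

In this assay, the replacement of 3-((dimethylamino)methyl)-5-methylphenyl by 4-((dimethylamino)methyl)-3-ethylphenyl gives a number 1.00 log units higher from compound 1 to compound 3 (beyond the scatter). On this aromatic carbon, a step beyond the scatter therefore appears with the dimethylamino group unchanged, so a change in the amine's substituents is not required. Compound 2 remains a limit of the assay, not a number: the limit of > 4.1 in this assay, at which 1 of the 3 values shown sits.

The step changes the ring substituents and their arrangement together, and the compounds shown do not separate the two. From the compounds shown here alone, how a morpholine in place of the dimethylamino group on 4-((dimethylamino)methyl)-3-ethylphenyl would read remains open.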